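The source may hold more compounds than are shown below. What is called first, only, known or untested is meant among the compounds shown, and "the series" means these compounds.

Measured compounds:
compound 1, `c1ccc(-c2nc(-c3c[nH]c4ccccc34)co2)cc1`, 170000 nM
compound 2, `Cc1nc(-c2c[nH]c3ccccc23)co1`, 337000 nM
compound 3, `c1ccc2c(-c3coc(-c4ccncc4)n3)c[nH]c2c1`, 298000 nM

In a functional assay on PC-3 cells (Homo sapiens) for cytotoxicity, read by MTT assay, with a stated time of 48 h (on this read-out higher numbers stand for weaker inhibition and lower numbers for stronger inhibition), the three measured compounds sit close together. Compound 3 stands with its value 298000 nM next to compound 2, separated by a 1.1-fold lower number from compound 2 to compound 3 (0.05 log units; within the scatter), and apart from compound 1 by a 1.8-fold higher number from compound 1 to compound 3 (0.24 log units; within the scatter); both gaps are within the scatter, so no order among the three is established.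

The next compound, compound 4, is `C=Cc1nc(-c2c[nH]c3ccccc23)co1`. It differs from compound 3 as follows: vinyl in place of pyridin-4-yl on an aromatic carbon.

Among the compounds with values here, the steps that bear on this change are those at the same aromatic carbon of the shared core: a 2.0-fold higher number from compound 1 to compound 2 (0.30 log units; within the scatter), a 1.8-fold higher number from compound 1 to compound 3 (0.24 log units; within the scatter) and a 1.1-fold lower number from compound 2 to compound 3 (0.05 log units; within the scatter). Phenyl, methyl and pyridin-4-yl at this position all gave numbers within the scatter of one another. Vinyl is a third small or flat replacement at that carbon, and on these three steps no move beyond the scatter is expected in this assay.

Compound 4 is therefore estimated at 300000 nM, in the range 150000 nM to 600000 nM, an expected step of a 1.0-fold higher number from compound 3 to compound 4 (0.00 log units; within the scatter) from compound 3.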

Compound 4, half-maximal inhibitory concentration: 426000 nM
For compound 4 the middle estimate is 1.4-fold (0.15 log units) below the measured one, within the range that was stated.
By their numbers in this assay, from the lowest: compounds 1, 3, 2 and 4 (each within the scatter of the next, the first and the last beyond it).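

In this assay, vinyl at this aromatic carbon cannot be told apart from pyridin-4-yl or methyl: a 1.4-fold higher number from compound 3 to compound 4 (0.16 log units; within the scatter), and a 1.3-fold higher number from compound 2 to compound 4 (0.10 log units; within the scatter). Vinyl in place of phenyl gives the only step in the series that passes the scatter, a 2.5-fold higher number from compound 1 to compound 4 (0.40 log units; beyond the scatter), although it is modest, so phenyl and vinyl are the only two groups at this position that are separated, while methyl and pyridin-4-yl remain within the scatter of both. Nothing measured here accounts for this separation.

Going by these compounds, it remains open whether an amine, a carboxylic acid or a longer chain at this carbon would give a number clearly lower than that of compound 1, at 170000 nM, or whether the values would stay in the same narrow band. Within the data shown here, also open is whether the one step beyond the scatter, which rests on a single pair of compounds, would carry over to other changes on the shared core.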